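The source may hold more compounds than are shown below. What is called first, only, known or untested is meant among the compounds shown, and "the series" means these compounds.

Compound 1 `Cc1ccc2[nH]c(C(=O)N[C@H]3CN(S(=O)(=O)c4ccccc4)C[C@@H]3C(=O)N[C@@H]3CCCN(C)C3)cc2c1` and compound 2 `Cc1ccc2[nH]c(C(=O)N[C@H]3CN(S(=O)(=O)c4ccccc4)C[C@@H]3C(=O)N[C@@H]3CCCNC3)cc2c1` are a matched pair whose single difference is hydrogen in place of methyl on an amine nitrogen in a ring. In an ADME assay on microsomes from liver (Homo sapiens) for metabolic stability (a higher number here means faster removal of the compound, a lower number slower removal), compound 1 gives 50 mL.min-1.g-1, while compound 2 gives 3 mL.min-1.g-1, so the step of a 17-fold lower number from compound 1 to compound 2 (1.22 log units; beyond the scatter). Compound 3 `Cc1ccc2[nH]c(C(=O)N[C@H]3CCN(S(=O)(=O)c4ccccc4Cl)C[C@@H]3C(=O)N[C@H]3CCCN(C)C3)cc2c1` carries a different core; the difference between the two cores is not broken down here. In this assay compound 3 gives 244 mL.min-1.g-1, the highest of the three numbers. Compound 4 `Cc1ccc2[nH]c(C(=O)N[C@H]3CCN(S(=O)(=O)c4ccccc4Cl)C[C@@H]3C(=O)N[C@H]3CCCNC3)cc2c1` is still unmeasured and differs from compound 3 by hydrogen in place of methyl on an amine nitrogen in a ring, the same change that was seen between compound 1 and compound 2. On the strength of that earlier step, a step of about a 17-fold lower number from compound 3 to compound 4 (1.24 log units; beyond the scatter) is expected here. Compound 4 is therefore estimated to give 14 mL.min-1.g-1 in this assay, most likely between 5 mL.min-1.g-1 and 45 mL.min-1.g-1.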

Compound 4, intrinsic clearance in microsomes in the Homo sapiens assay: 25 mL.min-1.g-1
Compound 4: middle estimate off by 1.8-fold (0.25 log units), on the low side, and the stated range covers the measured number.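

In the Homo sapiens assay, hydrogen in place of methyl on the amine nitrogen gives a 9.8-fold lower number from compound 3 to compound 4 (0.99 log units; beyond the scatter), and the change carries from one core to the other with the same direction and a size that cannot be told apart: the same change on two cores in the Homo sapiens assay, a 17-fold lower number (1.22 log units; beyond the scatter) from compound 1 to compound 2 and a 9.8-fold lower number (0.99 log units; beyond the scatter) from compound 3 to compound 4, 1.7-fold (0.23 log units) apart, within the scatter of two such steps. In a physicochemical assay for lipophilicity, measured as octanol-water partition, at pH 7.4 (on this read-out higher numbers stand for higher lipophilicity and lower numbers for lower lipophilicity), compound 3 gives 3.1 and compound 4 gives 1.9, so the two also move apart on the second core: the measured distribution coefficient of compound 3, 3.1, and of compound 4, 1.9, a number 1.20 log units lower (beyond the scatter). Two pairs make no rule for other cores, and this single lipophilicity pair does not show why removal falls.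

The compounds shown leave open how an acetyl group or a longer chain on that ring nitrogen would compare with hydrogen and methyl in the Homo sapiens assay. They also leave open whether lipophilicity moves alike on the core of compound 1.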